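Ester variation on a secoiridoid glucoside against SK-BR-3

The compounds below may be only part of what the source reports. "The series", "measured", "known", "first", "only" and "open" are said of these compounds alone.

The measured compounds:
Compound 1 `C/C=C1/[C@H](O[C@@H]2O[C@H](CO)[C@@H](O)[C@H](O)[C@H]2O)OC=C(C(=O)OC)[C@H]1CC(=O)OCc1ccco1` in a functional assay on SK-BR-3 cells (Homo sapiens) for antiproliferative activity, read by MTT assay, with a stated time of 72 h (on this read-out lower numbers stand for stronger inhibition and higher numbers for weaker inhibition), gives > 15000 nM, a limit of this assay.
Compound 2 `C/C=C1/[C@H](O[C@@H]2O[C@H](CO)[C@@H](O)[C@H](O)[C@H]2O)OC=C(C(=O)OC)[C@H]1CC(=O)O` gives > 15000 nM, again a limit.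
Compound 3 `C/C=C1/[C@H](O[C@@H]2O[C@H](CO)[C@@H](O)[C@H](O)[C@H]2O)OC=C(C(=O)OC)[C@H]1CC(=O)OCc1ccccc1` gives > 15000 nM, again a limit.

Compound 1 thus stands only at a limit, and so do the two other measured compounds, all sitting at the limit of > 15000 nM in this assay, at which 3 of the 3 values shown sit. None of the steps among them can be read: a step that the two limits leave unreadable from compound 1 to compound 2, a step that the two limits leave unreadable from compound 1 to compound 3 and a step that the two limits leave unreadable from compound 2 to compound 3 are all left unreadable by the two limits.

Compound 4 `C/C=C1/[C@H](O[C@@H]2O[C@H](CO)[C@@H](O)[C@H](O)[C@H]2O)OC=C(C(=O)OC)[C@H]1CC(=O)OCCc1ccc(O)cc1` differs from compound 1 by 4-hydroxybenzyl in place of furan-2-yl on a saturated chain carbon bound to an oxygen next to a carbonyl group. The three measured steps bear on it only in showing that a hydrogen, a (furan-2-yl)methyl and a benzyl on the same oxygen all leave the limit unbroken. Going by the values given here, no step of readable size is available, so the expected step from compound 1 to compound 4 is a step that the limit leaves unreadable from compound 1 to compound 4, with no direction that can be supported. Compound 4 is therefore estimated at 20000 nM, most likely again reported as a limit, in a range from 7000 nM to 60000 nM.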

Compound 4, half-maximal inhibitory concentration: > 20000 nM
Compound 4 gave a limit, no number; the forecaster's own chance of this, stated with the estimate: 85%; the middle value sits exactly at the limit.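

Compound 4 gives > 20000 nM, which is a limit and not a number. The steps from compound 1, compound 2 and compound 3 to compound 4 cannot be read. The compounds shown leave open whether any ester on the shared core gives a number in this assay, and how these esters rank.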